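A few compounds are considered here, and "the series" means these few. Any claim that something is new, unique, unknown or untested is made for them only; others in the source may bear on it.

In a functional assay on the whole organism for antagonist activity, with Rattus norvegicus as the target (on this read-out lower numbers stand for an effect already at smaller amounts and higher numbers for an effect only at larger amounts of compound), compound 3 (`CN1CCN(CCCCOc2cc(C(=O)N3CCCCc4sccc43)ccc2NC(=O)c2ccccc2-c2ccccc2)CC1`) is reported as < 0.01 mg/kg, which is a limit of the assay and not a number. Compound 1 (`O=C(Nc1ccc(C(=O)N2CCCN(Cc3ccccc3)c3sccc32)cc1)c1ccccc1-c1ccccc1`) is also known only as a limit, > 0.3 mg/kg. Compound 2 (`CN(C)C1CCN(C(=O)CCCOc2cc(C(=O)N3CCCCc4sccc43)ccc2NC(=O)c2ccccc2-c2ccccc2)CC1`) gives a true number, 0.005 mg/kg.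

Compound 4 (`CN(C)C1CCN(C(=O)COc2cc(C(=O)N3CCCCc4sccc43)ccc2NC(=O)c2ccccc2-c2ccccc2)CC1`), not yet measured, carries (4-(dimethylamino)piperidin-1-yl)carbonyl in place of 3-(4-methylpiperazin-1-yl)propyl on a saturated chain carbon bound to an oxygen on an aromatic ring.

Going by the values given here, only one measured step bears on this change: a step that the limit leaves unreadable from compound 2 to compound 3. It offers no size to carry over. Compound 2 does hold the same (4-(dimethylamino)piperidin-1-yl)carbonyl that enters compound 4, but there the group sits three bonds along the chain from an oxygen on an aromatic ring. Compound 2, at 0.005 mg/kg, is therefore the closest readable anchor, though an imperfect one. On that basis, no clear shift beyond the scatter is expected in this assay, and no direction can be argued with confidence. The estimated step is a number no lower from compound 3 to compound 4 (the limit leaves the size open). For compound 4 the estimate is 0.01 mg/kg, with an expected range from 0.003 mg/kg to 0.04 mg/kg.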

Compound 4, dose for 50% inhibition: 0.02 mg/kg
Estimate against measurement, compound 4: 2.0-fold (0.30 log units) below; the measured number falls inside the stated range.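

In this assay, going by these compounds alone, setting (4-(dimethylamino)piperidin-1-yl)carbonyl in place of 3-(4-methylpiperazin-1-yl)propyl on a saturated chain carbon bound to an oxygen on an aromatic ring gives an at least 2.0-fold higher number from compound 3 to compound 4 (0.30 log units; that floor lies within the scatter), the only step at this position that can be read at all, and its floor does not by itself separate the two compounds. From the compounds shown here alone, the value of compound 3 is a limit and not a number, so the true size of this step stays open: the limit of < 0.01 mg/kg in this assay, at which 1 of the 4 values shown sits.

With the same amide-bearing group in both, compound 2 gives 0.005 mg/kg and compound 4, which carries ((4-(dimethylamino)piperidin-1-yl)carbonyl)methyl, gives 0.02 mg/kg, a higher number that shows the length of the chain can count alongside the group at its end.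

The change from compound 3 to compound 4 alters the carbonyl and the ring together, and the compounds shown do not tell these two apart; a (4-methylpiperazin-1-yl)carbonyl group would do so. Going by these compounds, how a morpholine or a carboxylic acid in place of these groups would read in this assay also remains unknown.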